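Swapping a Ring Oxygen-Bearing Group for an All-Carbon Ring

A few compounds are considered here, and "the series" means these few. Any claim that something is new, unique, unknown or untested is made for them only; others in the source may bear on it.

Going by the values given here, compound 2 `C[C@@H]1CN(c2ccc(-c3n[nH]c4cnc(N5[C@H](C)COC[C@@H]5C)nc34)cn2)CCN1` is one of two compounds measured in an assay on Sf9 cells for inhibition of activin receptor type-1 (Homo sapiens), read by HTRF, with a stated time of 3 h, in the presence of a further agent that is not named here; a higher number here means a weaker inhibitor, a lower number a stronger inhibitor. In this assay compound 2 gives 23 nM, the higher of the two numbers, so it is the weaker inhibitor of the pair. Compound 1 `COC(=O)N1C[C@@H](C)N(c2ncc3[nH]nc(-c4ccc(N5CCN(C)CC5)cc4)c3n2)[C@@H](C)C1` gives 0.98 nM, and the gap between these two values lies beyond the usual scatter; the two structures differ in more than one place, so no single change accounts for it. Compound 3 `C[C@@H]1CN(c2ccc(-c3n[nH]c4cnc(N5[C@H](C)CCC[C@@H]5C)nc34)cn2)CCN1` is not yet measured. It differs from compound 2 in one place: 2,6-dimethylpiperidin-1-yl in place of 3,5-dimethylmorpholin-4-yl on an aromatic carbon. Among the compounds with values here, no measured pair differs by this kind of change alone, so there is no direct guide to its size. Both groups are six-membered non-aromatic rings with two defined stereocentres, and the expected step of a 1.2-fold lower number from compound 2 to compound 3 (0.06 log units; within the scatter) is small, within the usual scatter, in no firm direction. Compound 3 is estimated at 20 nM, with a likely range from 6 nM to 70 nM.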

Compound 3, half-maximal inhibitory concentration: 2.5 nM
Estimate against measurement, compound 3: 8.0-fold (0.90 log units) above; measured number below the stated range.
By their numbers in this assay, from the lowest: compound 1; then compound 3; then compound 2.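

In this assay, going by these compounds alone, placing 2,6-dimethylpiperidin-1-yl instead of 3,5-dimethylmorpholin-4-yl on this aromatic carbon, between two ring nitrogen atoms, gives a 9.2-fold lower number from compound 2 to compound 3 (0.96 log units; beyond the scatter) and is the first change here that can be read on its own. The two groups have the same number of heavy atoms and defined stereocentres, and the entering ring has a carbon where the leaving ring has its oxygen, so even this small swap registers clearly at this position. Nothing available here explains the step.

The compounds shown leave open whether the two ring methyl groups contribute to this result, which a piperidine ring without them would test. They also leave open whether an open-chain group such as diethylamino would serve at this position.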